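This account rests on a few compounds, and the source may have more. Where it says the series, first, only, none or still open, it means among the compounds named here.

Series notes on the cytotoxicity read-out. Within the data shown here, compound 1 `O=C1CSC(c2cccc(F)c2)N1CCN1CCCCC1` gives 97% in an ADME assay on Vero cells (Chlorocebus sabaeus) for cytotoxicity, read by neutral red uptake, tested at 49 ug/mL (on this read-out lower numbers stand for a stronger effect and higher numbers for a weaker effect at the one concentration tested), the second highest of the three numbers so far. Among the measured compounds shown here, compound 3 `O=C1CSC(c2ccccc2[N+](=O)[O-])N1CCN1CCCCC1` gives 100%, within the scatter of compound 1, while compound 2 `O=C1CSC(c2ccc(Cl)cc2)N1CCN1CCCCC1` gives 84%, the one value set apart. For the measured compounds named here, the only single-site step on record is a number 13 percentage points lower from compound 1 to compound 2 (beyond the scatter). Compound 4 `O=C1CSC(c2cccc(Cl)c2)N1CCN1CCCCC1` is next; against compound 1 the change is chloro in place of fluoro on an aromatic carbon. The step from compound 1 to compound 2 is the only one that bears on it, since it also swaps fluoro for chloro, though at a different place on the ring; compound 3 offers no parallel. On that basis a modest drop is expected, a number 7 percentage points lower from compound 1 to compound 4 (within the scatter), so compound 4 is estimated at 90%, between 78% and 100%.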

Compound 4, a percentage reported as activity, at one concentration (the size of the read-out at that concentration, not a potency): 100%
For compound 4 the middle estimate is 10 percentage points below the measured one, within the range that was stated.
By their numbers in this assay, from the lowest: compound 2; then compounds 1, 3 and 4 (each within the scatter of the next).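

On the aromatic carbon of the 3-fluorophenyl group, chloro in place of fluoro gives no shift beyond the scatter in this assay (a number 3 percentage points higher from compound 1 to compound 4 (within the scatter)). With chloro on both compounds, 3-chlorophenyl in place of 4-chlorophenyl gives a step beyond the scatter (a number 16 percentage points higher from compound 2 to compound 4 (beyond the scatter)), so the lower number of compound 2 goes with 4-chlorophenyl and not with chloro as such. No measurement at hand explains this difference.

Open, as far as these compounds go, is whether 4-fluorophenyl gives a number as low as 4-chlorophenyl does. Also open, from the compounds shown here alone, is how a methoxy group or an amine on the aromatic ring would read.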